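The source may hold more compounds than are shown below. What is called first, only, known or untested is meant among the compounds shown, and "the series" means these compounds.

Measured in a functional assay on HCT-116 cells (Homo sapiens) for inhibition, read by MTT assay, with a stated time of 48 h; on this read-out lower numbers stand for stronger inhibition and higher numbers for weaker inhibition:
- compound 1 `COc1ccc(C/N=C2\NC(=O)/C(=C3\CCNC(=O)c4[nH]ccc43)S2)cc1`: 19400 nM
- compound 2 `O=C1N/C(=N\Cc2ccc(C(F)(F)F)cc2)S/C1=C1/CCNC(=O)c2[nH]ccc21`: > 100000 nM, a limit of the assay
- compound 3 `O=C1N/C(=N\Cc2ccccc2Cl)S/C1=C1/CCNC(=O)c2[nH]ccc21`: > 50000 nM, a limit of the assay

Compound 1 is the only one of the three with an actual number in this assay, and that number is the lowest shown. Compound 4 `Cc1ccc(C/N=C2\NC(=O)/C(=C3\CCNC(=O)c4[nH]ccc43)S2)cc1` differs from it by methyl in place of methoxy on an aromatic carbon, para to a large group (methyl in place of methoxy on an aromatic carbon).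

For the measured compounds named here, two measured steps bear on this change. The closer one replaces the same methoxy with trifluoromethyl, giving an at least 5.1-fold higher number from compound 1 to compound 2 (0.71 log units; beyond the scatter). The other is 2-chlorophenyl in place of 4-methoxyphenyl, giving an at least 2.5-fold higher number from compound 1 to compound 3 (0.41 log units; beyond the scatter). Both moved to higher numbers, so a modest rise is expected here too, although neither step tested methyl itself. The expected change is a 2.1-fold higher number from compound 1 to compound 4 (0.31 log units; beyond the scatter). For compound 4 the estimate is 40000 nM, with an expected range from 14000 nM to 110000 nM.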

Compound 4, half-maximal inhibitory concentration: 4760 nM
Beside the measured number, compound 4's estimate is 8.4-fold (0.92 log units) above it; measured number outside the range, below it.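

In this assay, methyl in place of methoxy on this aromatic carbon, para to a large group, moves the read-out the opposite way from the earlier steps, with a 4.1-fold lower number from compound 1 to compound 4 (0.61 log units; beyond the scatter), so a change here can also lower the number, and compound 4 now has the lowest number shown. The choice of group at this place matters in both directions: methyl in place of trifluoromethyl gives an at least 21-fold lower number from compound 2 to compound 4 (1.32 log units; beyond the scatter), and 4-methylphenyl in place of 2-chlorophenyl gives an at least 10-fold lower number from compound 3 to compound 4 (1.02 log units; beyond the scatter). Compound 2 and compound 3 each stand at a limit of the assay rather than a number, so these two steps give only a minimum size.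

The compounds shown leave open whether an ethyl group or a longer chain at this place would keep the lower number seen with methyl. They also leave open how an amine, a carboxylic acid or a plain hydrogen there would read.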